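The source may hold more compounds than are shown below. What is called first, only, known or untested is meant among the compounds shown, and "the series" means these compounds.

Measured so far:
compound 1, `COc1cc(-c2cc(C(=O)/C=C/c3ccc(Cl)cc3)nc3cc(-c4ccccc4)nn23)cc(OC)c1OC`, in a functional assay on DU-145 cells (Homo sapiens) for antiproliferative activity, read by MTT assay, with a stated time of 24 h (a higher number here means a weaker inhibitor, a lower number a stronger inhibitor), gives 19500 nM
compound 2, `COc1ccc(-c2cc(C(=O)/C=C/c3ccc(Cl)cc3)nc3cc(-c4ccccc4)nn23)cc1OC`, in this assay gives 22400 nM
compound 3, `COc1ccc(C(=O)/C=C/c2cc(-c3ccc(OC)cc3)n3nc(-c4ccccc4)cc3n2)cc1`, in this assay gives 8500 nM

Compound 2 holds the highest of the three numbers. Compound 1 sits nearest to it, and the two lie within the scatter of each other, as the step of a 1.1-fold higher number from compound 1 to compound 2 (0.06 log units; within the scatter) shows. Compound 3 gives the lowest number, beyond the scatter from compound 2.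

Compound 4, `COc1ccc(-c2cc(/C=C/C(=O)c3ccccc3)nc3cc(-c4ccccc4)nn23)cc1OC`, is not yet measured. From compound 2 it differs in one place: 2-benzoylethenyl in place of (2-(4-chlorophenyl)ethenyl)carbonyl on an aromatic carbon. For the measured compounds named here, no measured step bears directly on this change; the only known step, a 1.1-fold higher number from compound 1 to compound 2 (0.06 log units; within the scatter), concerns a methoxy and was within the scatter. Compound 3 carries a related benzoylethenyl arrangement but differs from compound 2 in more than one place, so its number is only a hint. Since compound 3 gives 8500 nM, a somewhat lower number than compound 2 is expected, with wide uncertainty. The expected step for compound 4 is a 1.7-fold lower number from compound 2 to compound 4 (0.24 log units; within the scatter). Compound 4 is estimated at 13000 nM, within a range from 4000 nM to 40000 nM.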

Compound 4, half-maximal inhibitory concentration: 10000 nM
The estimate for compound 4 lay 1.3-fold (0.11 log units) above the measured number; measured number inside the range.
By their numbers in this assay, from the lowest: compounds 3, 4, 1 and 2 (each within the scatter of the next, the first and the last beyond it).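

In this assay, for the compounds shown here, the position carrying the enone chain responds to substitution: a 2.2-fold lower number from compound 2 to compound 4 (0.35 log units; beyond the scatter), a modest step but the first single-place change to lie beyond the scatter, since the earlier methoxy step did not. The replacement of (2-(4-chlorophenyl)ethenyl)carbonyl by 2-benzoylethenyl does two things at once, removing the chlorine and reversing the order of carbonyl and ethenyl in the chain, so this pair cannot assign the step to either one. Nothing at hand gives a cause for the step.

A 2-(4-chlorobenzoyl)ethenyl group at this position would separate the two contributions. From the compounds shown here alone, how a chain ending in an amine or a carboxylic acid would read here also remains open.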